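Working notes: cytotoxicity series, compound 4 pending

The source may report more compounds than this note shows. Statements on the series, on what has been measured and on what is new or still open speak of the compounds shown alone.

Measured so far:
compound 1 `Nc1sc2c(c1-c1nc3cc(Cl)ccc3s1)CCC2` — 75.1 ug/mL
compound 2 `Fc1ccccc1/C=N/c1sc2c(c1-c1nc3ccccc3s1)CCC2` — 355 ug/mL
compound 3 `Clc1ccccc1/C=N/c1sc2c(c1-c1nc3ccccc3s1)CCCC2` — 407 ug/mL

In an ADME assay on HeLa cells (Homo sapiens) for cytotoxicity, read by MTT assay, with a stated time of 72 h (on this read-out higher numbers stand for lower toxicity in this test and lower numbers for higher toxicity in this test), compound 1 gives 75.1 ug/mL, the lowest of the three numbers recorded. Compound 2 gives 355 ug/mL and compound 3 gives 407 ug/mL; both stand above compound 1 by margins beyond the usual scatter, so compound 1 is the most cytotoxic of the three in this assay.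

Compound 4, `Oc1ccccc1/C=N/c1sc2c(c1-c1nc3cc(Cl)ccc3s1)CCC2`, derives from compound 1 by the change (a group of 9 heavy atoms (7 carbon, 1 nitrogen, 1 oxygen; one six-membered aromatic ring of carbon only) in place of one nitrogen atom, on an aromatic carbon). Among the measured compounds shown here, no measured pair shows exactly this step, so its size is not known directly. What the numbers do show is that compound 2 and compound 3 both carry a six-membered aromatic ring joined through a double bond outside aromatic rings in place of the amino group; compound 2 gives 355 ug/mL and compound 3 gives 407 ug/mL, both clearly above compound 1.

On that basis the step from compound 1 to compound 4 is expected to be upward and beyond the scatter, estimated as a 3.3-fold higher number from compound 1 to compound 4 (0.52 log units; beyond the scatter). For compound 4 the expected value in this assay is 250 ug/mL, with a range from 90 ug/mL to 500 ug/mL.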

Compound 4, half-maximal cytotoxic concentration: 251 ug/mL
Compound 4: the middle estimate sits 1.0-fold (0.00 log units) below what was measured; the measured number falls inside the stated range.
By their numbers in this assay, from the lowest: compound 1; then compounds 4, 2 and 3 (each within the scatter of the next).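

Working notes, compound 4: on the core of compound 1, putting the group of compound 4 in place of the amino group, on the aromatic carbon next to the ring sulfur, gives in this assay a 3.3-fold higher number from compound 1 to compound 4 (0.52 log units; beyond the scatter). Among the compounds shown here, this is the first pair that differs in one place, so the size of this change at this position can now be read directly, with the rest of the core held fixed. On this core the larger group therefore goes with lower toxicity in this test, not higher, and no supporting measurement bears on the reason for the step.

The compounds shown leave open how much of the step belongs to the six-membered aromatic ring and how much to the hydroxyl group on it. A methoxy group or a carboxylic acid in place of that hydroxyl group, on the same core, would begin to separate the two.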